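Same Selenium Swap Tried on a Second Core

The source may report more compounds than this note shows. Statements on the series, on what has been measured and on what is new or still open speak of the compounds shown alone.

The measured compounds are:
compound 1 `CS/C(=N\C(=O)c1csc([N+](=O)[O-])c1)NC(=O)c1csc([N+](=O)[O-])c1`: 82500 nM
compound 2 `O=C(/N=C(/NC(=O)c1cccs1)[Se]Cc1ccccc1)c1cccs1`: > 100000 nM
compound 3 `CS/C(=N\C(=O)c1cccs1)NC(=O)c1cccs1`: 98300 nM

Of the compounds shown here, three have been tested in a functional assay on PC-3 cells (Homo sapiens) for cytotoxicity, read by MTT assay, with a stated time of 72 h; a lower number here means a stronger inhibitor of growth, a higher number a weaker inhibitor of growth. Compound 3 gives 98300 nM. Compound 1 gives 82500 nM in this assay; set next to compound 3 the two values are within the usual scatter, so no order between them can be read. How the core of compound 1 differs from the core of compound 3 is not broken down here. For compound 2 the assay returned only a limit, > 100000 nM, and not a number. The step from compound 3 to compound 2 is therefore itself bounded: an at least 1.0-fold higher number from compound 3 to compound 2 (0.00 log units; that floor lies within the scatter). The change behind that step is a group of 8 heavy atoms (7 carbon, 1 selenium; one six-membered aromatic ring of carbon only) in place of a group of 2 heavy atoms (1 carbon, 1 sulfur; no ring), on a carbon with a double bond to nitrogen. Of the three values shown, one sits at the limit of > 100000 nM in this assay, at which 1 of the 3 values shown sits.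

Compound 4 `O=C(/N=C(/NC(=O)c1csc([N+](=O)[O-])c1)[Se]Cc1ccccc1)c1csc([N+](=O)[O-])c1` has not yet been measured in this assay. It differs from compound 1 by a group of 8 heavy atoms (7 carbon, 1 selenium; one six-membered aromatic ring of carbon only) in place of a group of 2 heavy atoms (1 carbon, 1 sulfur; no ring), on a carbon with a double bond to nitrogen, the same kind of change as that from compound 3 to compound 2, made at the same place. Since compound 3 to compound 2 gave an at least 1.0-fold higher number from compound 3 to compound 2 (0.00 log units; that floor lies within the scatter) and compound 1 gives 82500 nM, compound 4 is expected to show a step of about a 1.6-fold higher number from compound 1 to compound 4 (0.20 log units; within the scatter). Compound 4 is thus estimated at 130000 nM, with a range of 60000 nM to 300000 nM, and a real chance that the assay again reports only a limit.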

Compound 4, concentration for total growth inhibition: 69200 nM
For compound 4 the middle estimate is 1.9-fold (0.27 log units) above the measured one; the range from low to high includes it.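

On the core of compound 1, putting the group of 8 heavy atoms, with its selenium and its six-membered aromatic ring, in place of methylsulfanyl gives a 1.2-fold lower number from compound 1 to compound 4 (0.08 log units; within the scatter) in this assay, so no order between these two compounds can be read. Neither core shows a step beyond the scatter for this change, so the compounds give no sign that it shifts growth inhibition on either core, yet this does not show that the change behaves the same on both: the same change on two cores in this assay, an at least 1.0-fold higher number (0.00 log units; that floor lies within the scatter) from compound 3 to compound 2 and a 1.2-fold lower number (0.08 log units; within the scatter) from compound 1 to compound 4; the limit leaves it open whether they differ For compound 2 the value > 100000 nM is a limit of the assay and not a number, so the step on the core of compound 3 has only a floor and no size of its own.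

The compounds shown leave open how a benzylsulfanyl group, with sulfur where the selenium stands, would read on either core, so the selenium is not separated from the six-membered aromatic ring that comes with it. Also open, on these data alone, is whether an amine or a longer alkyl chain, on the carbon with a double bond to nitrogen, would give a step beyond the scatter.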